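From methoxy to butoxy: one chain grows longer

The source may hold more compounds than are shown below. What is called first, only, known or untested is meant among the compounds shown, and "the series" means these compounds.

- compound 1 `CCOC[C@H]1O[C@@H](n2c(Cl)nc3cc(Cl)c(Cl)cc32)[C@H](OC(C)=O)[C@@H]1OC(C)=O`: 33000 nM
- compound 2 `CSCC1OC(n2c(Cl)nc3cc(Cl)c(Cl)cc32)C(OC(C)=O)C1OC(C)=O`: 32000 nM
- compound 3 `COC[C@H]1OC(n2c(Cl)nc3cc(Cl)c(Cl)cc32)[C@H](O)[C@@H]1O`: 32000 nM

All three values come from a functional assay on HFF cells (Homo sapiens) for cytotoxicity; on this read-out higher numbers stand for weaker inhibition and lower numbers for stronger inhibition. Compound 3 stands level with compound 2 at the digits given, and compound 1 also lies within the usual scatter of both. No two of these compounds differ in only one place, so no single structural change has yet been measured on its own.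

Compound 4 `CCCCOC[C@H]1OC(n2c(Cl)nc3cc(Cl)c(Cl)cc32)[C@H](O)[C@@H]1O` keeps the core of compound 3 but carries butoxymethyl instead of methoxymethyl, with propyl in place of hydrogen on a saturated chain carbon bound to an oxygen on a saturated carbon. Going by the values given here, with no measured step to guide the size, a step in this assay that stays within the scatter is expected, leaning if anything towards a slightly lower number. The expected change is a 1.3-fold lower number from compound 3 to compound 4 (0.11 log units; within the scatter). For compound 4 the estimated value is 25000 nM, with an expected range from 10000 nM to 60000 nM.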

Compound 4, half-maximal inhibitory concentration: 32000 nM
Estimate against measurement, compound 4: 1.3-fold (0.11 log units) below, and the stated range covers the measured number.
By their numbers in this assay, from the lowest: compounds 2, 3, 4 and 1 (each within the scatter of the next).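

Going by these compounds alone, this is the first single change that can be read on its own: in this assay, going from methoxymethyl to butoxymethyl, with propyl in place of hydrogen on a saturated chain carbon bound to an oxygen on a saturated carbon, gives no change at the digits printed from compound 3 to compound 4 (within the scatter). On this read-out, then, the position takes the longer chain with no visible shift in the number, at least for this one step. Nothing measured here explains why the number holds steady.

As far as these compounds go, whether an octyl chain, or a chain ending in an amine or a carboxylic acid, would leave the number equally unmoved at this position remains open. One step also cannot show whether the same lengthening would behave alike on a compound carrying a different group elsewhere on the shared core.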